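Series notes: from compound 3 to compound 4

The compounds below may be only part of what the source reports. "The series", "measured", "known", "first", "only" and "open" are said of these compounds alone.

Measured values in a functional assay on HepG2 cells (Homo sapiens) for antiproliferative activity, read by MTT assay, with a stated time of 48 h (on this read-out lower numbers stand for stronger inhibition of growth and higher numbers for weaker inhibition of growth), are as follows.
- Compound 1 (`COc1cc(C2CC(c3ccccc3)=NN2C(=O)OCc2ccccc2)cc(OC)c1OC`): > 10000 nM (a limit of the assay, not a number)
- Compound 2 (`CCOc1cccc(C2=NN(C(=O)OC)C(c3cc(OC)c(OC)c(OC)c3)C2)c1`): 8360 nM
- Compound 3 (`COC(=O)N1N=C(c2cccc(C)c2)CC1c1cc(OC)c(OC)c(OC)c1`): 980 nM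

Of the two actual numbers, the lower belongs to compound 3 (980 nM).

Compound 4 (`COC(=O)N1N=C(c2ccc(OC)c(OC)c2)CC1c1cc(OC)c(OC)c(OC)c1`) carries 3,4-dimethoxyphenyl in place of 3-methylphenyl on a carbon with a double bond to nitrogen.

Within the data shown here, one measured step bears on this change. Methyl in place of ethoxy on an aromatic carbon gave a modest move (an 8.5-fold lower number from compound 2 to compound 3 (0.93 log units; beyond the scatter)), beyond the scatter. Compound 4 gives up the same methyl group and gains methoxy groups, so it is expected to lean towards the ethoxy compound 2 (8360 nM). This expectation rests on a single step, so it is loose.

A step of similar or smaller size is expected, towards a higher number in this assay (a 3.6-fold higher number from compound 3 to compound 4 (0.55 log units; beyond the scatter)). For compound 4 the estimated value is 3500 nM (expected range 1000 nM to 10000 nM).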

Compound 4, concentration for 50% growth inhibition: 4210 nM
For compound 4 the middle estimate is 1.2-fold (0.08 log units) below the measured one, within the range that was stated.
By their numbers in this assay, from the lowest: compound 3; then compounds 4 and 2 (each within the scatter of the next). At a limit, above all of these: compound 1.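

In this assay, the aryl group on the carbon with a double bond to nitrogen proves sensitive to a second kind of change: 3,4-dimethoxyphenyl in place of 3-methylphenyl gives a 4.3-fold higher number from compound 3 to compound 4 (0.63 log units; beyond the scatter). Set against the 3-ethoxyphenyl group, the same 3,4-dimethoxyphenyl group gives a 2.0-fold lower number from compound 2 to compound 4 (0.30 log units; within the scatter), so these two oxygen-bearing aryl groups cannot be told apart here, and among the three measured aryl groups with the methoxycarbonyl group only 3-methylphenyl stands apart from the others. No measurement shown accounts for this step.

As far as these compounds go, it remains open whether the lower number of compound 3 is specific to methyl or would also hold for a chlorine atom or a longer alkyl chain on the aryl ring. From the compounds shown here alone, how an amine or a carboxylic acid on that ring would behave is also open.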